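The source may hold more compounds than are shown below. What is called first, only, known or untested is meant among the compounds shown, and "the series" means these compounds.

Three compounds that share one core and differ only in the aromatic ring carried on a ring nitrogen have been tested in a functional assay on A549 cells (Homo sapiens) for cytotoxicity, read by MTT assay, with a stated time of 72 h; on this read-out higher numbers stand for weaker inhibition and lower numbers for stronger inhibition. Compound 1 `Cc1cc(=O)n(-c2ccc(Br)cc2F)nc1C(=O)Nc1ccc(Oc2ncnc3ccsc23)cc1` gives 7930 nM, compound 2 `Cc1cc(=O)n(-c2ccc(F)cc2)nc1C(=O)Nc1ccc(Oc2ncnc3ccsc23)cc1` gives 2360 nM, and compound 3 `Cc1cc(=O)n(-c2ccc(F)c(F)c2)nc1C(=O)Nc1ccc(Oc2ncnc3ccsc23)cc1` gives 8180 nM. On these numbers compound 3 stands at the top of the three, although its gap to compound 1 is within the scatter. The steps among them are a 3.4-fold lower number from compound 1 to compound 2 (0.53 log units; beyond the scatter), a 1.0-fold higher number from compound 1 to compound 3 (0.01 log units; within the scatter) and a 3.5-fold higher number from compound 2 to compound 3 (0.54 log units; beyond the scatter). Compound 4 `Cc1ccc(-n2nc(C(=O)Nc3ccc(Oc4ncnc5ccsc45)cc3)c(C)cc2=O)c(C)c1` has not yet been measured; its change from compound 3 is 2,4-dimethylphenyl in place of 3,4-difluorophenyl on an aromatic nitrogen. Within the data shown here, no measured step swaps a fluorine-bearing ring for a methyl-bearing one, and none bears on this change directly. What the set does show is that the rings with two substituents, in compound 1 and compound 3, sit at higher numbers than the ring with one, in compound 2. Compound 4 also carries two substituents on that ring, and the expected step is a 1.3-fold lower number from compound 3 to compound 4 (0.10 log units; within the scatter), small and within the scatter. The estimate for compound 4 is 6500 nM, between 2000 nM and 22000 nM.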

Compound 4, half-maximal inhibitory concentration: 16400 nM
The estimate for compound 4 lay 2.5-fold (0.40 log units) below the measured number, within the range that was stated.
By their numbers in this assay, from the lowest: compound 2; then compounds 1, 3 and 4 (each within the scatter of the next, the first and the last beyond it).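

In this assay, among these compounds, the 2,4-dimethylphenyl ring is the first one on this nitrogen with no halogen, and it cannot be told apart from the 3,4-difluorophenyl ring (a 2.0-fold higher number from compound 3 to compound 4 (0.30 log units; within the scatter)). It does separate from the two other rings, with the largest step in the set against the single-substituent ring (a 6.9-fold higher number from compound 2 to compound 4 (0.84 log units; beyond the scatter)) and a much smaller one against the bromo-fluoro ring (a 2.1-fold higher number from compound 1 to compound 4 (0.32 log units; beyond the scatter)). All three rings with two substituents now give higher numbers than the single-substituent ring of compound 2, none of the four goes against this, and nothing measured here explains it.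

From the compounds shown here alone, whether the count of substituents or their placement drives this remains open. So does how a ring carrying an amine or a carboxylic acid would behave at this position.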